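Aryl substitution on the amide-type nitrogen: compound 4

The source may hold more compounds than are shown below. What is called first, only, known or untested is meant among the compounds shown, and "the series" means these compounds.

The series shares one core, varied only at the aromatic ring on the amide-type nitrogen. Compound 1 `COc1cc2ncnc(NCc3cccc(NC(=O)Nc4ccccc4)c3)c2cc1OC` carries an unsubstituted phenyl there, and in a functional assay on MGC-803 cells (Homo sapiens) for antiproliferative activity, read by MTT assay (a higher number here means a weaker inhibitor, a lower number a stronger inhibitor), compound 1 gives 10000 nM. Compound 2 `COc1cc2ncnc(NCc3cccc(NC(=O)Nc4ccccc4Cl)c3)c2cc1OC` gives 30200 nM, and compound 3 `COc1cc2ncnc(NCc3cccc(NC(=O)Nc4ccc(Cl)cc4)c3)c2cc1OC` gives 44200 nM. Compound 3 thus stands at the highest number of the three: a 4.4-fold higher number from compound 1 to compound 3 (0.65 log units; beyond the scatter), whereas the gap a 1.5-fold higher number from compound 2 to compound 3 (0.17 log units; within the scatter) leaves compounds 2 and 3 level with each other.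

Compound 4 `COc1cc2ncnc(NCc3cccc(NC(=O)Nc4cccc(C(F)(F)F)c4)c3)c2cc1OC` is the next entry: 3-(trifluoromethyl)phenyl in place of 4-chlorophenyl on an amide-type nitrogen. Two kinds of measured step bear on it. Putting a chloro on the phenyl raised the number in both cases, a 3.0-fold higher number from compound 1 to compound 2 (0.48 log units; beyond the scatter) and a 4.4-fold higher number from compound 1 to compound 3 (0.65 log units; beyond the scatter), so a substituted phenyl has so far given a higher number than the bare ring. Exchanging one chlorophenyl for the other, a 1.5-fold higher number from compound 2 to compound 3 (0.17 log units; within the scatter), changed little. Compound 4 keeps a single substituent on the phenyl, but of a different kind; nothing measured separates trifluoromethyl from chloro. The expectation for compound 4 is therefore a step of about a 1.1-fold lower number from compound 3 to compound 4 (0.04 log units; within the scatter), that is, none beyond the scatter in this assay. The estimated value for compound 4 is 40000 nM, with a range from 15000 nM to 100000 nM.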

Compound 4, half-maximal inhibitory concentration: > 50000 nM
Compound 4 ended at the assay's limit; the forecaster's own chance of this, stated with the estimate: 15%; at least 1.2-fold (0.09 log units) between middle value and limit.
By their numbers in this assay, from the lowest: compound 1; then compounds 2 and 3 (each within the scatter of the next). At a limit, above all of these: compound 4.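

Notes on the aryl position: in this assay compound 4 gives > 50000 nM, which is a limit of the assay and not a number: the limit of > 50000 nM in this assay, at which 1 of the 4 values shown sits.

Trifluoromethyl on the phenyl thus joins chloro in giving a higher number than the bare ring, an at least 5.0-fold higher number from compound 1 to compound 4 (0.69 log units; beyond the scatter), so among the compounds shown a single substituent at this position has not improved on the unsubstituted phenyl, and no compound shown goes against this. The comparisons with the two chlorophenyl compounds are weaker, since the floors of an at least 1.1-fold higher number from compound 3 to compound 4 (0.05 log units; that floor lies within the scatter) and an at least 1.6-fold higher number from compound 2 to compound 4 (0.21 log units; that floor lies within the scatter) both lie within the scatter and so set no order among the three substituted compounds.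

The change from 4-chlorophenyl to 3-(trifluoromethyl)phenyl alters the group and its place on the ring together, so the compounds shown do not separate these two changes. Going by these compounds, whether any substituent on this phenyl can give a lower number than compound 1 at 10000 nM also stays open, for instance an amine, a methoxy group or a carboxylic acid.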